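The source may report more compounds than this note shows. Statements on the series, on what has been measured and on what is new or still open speak of the compounds shown alone.

Among the measured compounds shown here, compound 3, with the structure `CCCCNc1nnc(COc2ccc(-c3ccccc3)cc2)o1`, stands lowest among the three compounds measured so far: in a functional assay on the whole organism (strain Wistar) for inhibition, with Rattus norvegicus as the target, read by paw edema, with a stated time of 3 h, at a dose of 10 mg/kg by the oral route (on this read-out lower numbers stand for less inhibition and higher numbers for more inhibition at the one dose given (going by the name of the read-out)), compound 3 gives 15.9%. Compound 1, with the structure `Clc1ccc(-c2nnc(COc3ccc(-c4ccccc4)cc3)o2)cc1`, gives 75%, and compound 2, with the structure `Clc1ccc(-c2nnc(COc3ccc(-c4ccccc4)cc3)o2)c(Cl)c1`, gives 56.1%. The steps leading down to compound 3 are large: a number 59.1 percentage points lower from compound 1 to compound 3 (beyond the scatter) and a number 40.2 percentage points lower from compound 2 to compound 3 (beyond the scatter), both beyond the scatter, so the swap of an aryl group on the shared core for a butylamino group cost most of the inhibition. The step to compound 4, with the structure `Fc1ccc(Nc2nnc(COc3ccc(-c4ccccc4)cc3)o2)cc1`, is 4-fluorophenyl in place of butyl on a nitrogen on an aromatic ring. For the measured compounds named here, no measured pair shows exactly this change; the two steps above bear on it only in that an aromatic ring on the core went with higher numbers and an alkylamino group with the lowest. Since compound 4 brings an aromatic ring back, though on the nitrogen, a modest rise is expected: a number 19.1 percentage points higher from compound 3 to compound 4 (beyond the scatter). Compound 4 is therefore estimated at 35%, within a range from 10% to 60%, and the continuation will report what was found.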

Compound 4, a percentage reported as inhibition, in the whole organism at one dose (the size of the read-out at that dose, not a potency): 52.3%
Estimate against measurement, compound 4: 17.3 percentage points below; low and high end bracket the measured number.
By their numbers in this assay, from the lowest: compound 3; then compounds 4 and 2 (each within the scatter of the next); then compound 1.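

In this assay, changing only what the nitrogen on the shared core carries, from butyl to 4-fluorophenyl, gives a large step (a number 36.4 percentage points higher from compound 3 to compound 4 (beyond the scatter)). The low number of compound 3 therefore does not go with the amino link as such, since the (4-fluorophenyl)amino compound lies within the scatter of the 2,4-dichlorophenyl compound (a number 3.8 percentage points lower from compound 2 to compound 4 (within the scatter)), while the 4-chlorophenyl compound stays clearly apart (a number 22.7 percentage points lower from compound 1 to compound 4 (beyond the scatter)). No measurement at hand explains why this change has such an effect.

With only butyl and 4-fluorophenyl on this nitrogen, the compounds shown cannot separate the part played by the ring from that of the fluorine, which a plain phenyl group would do. As far as these compounds go, it also remains open how a benzyl or cyclohexyl group would read on the same nitrogen.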